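Swapping the Amino Group on a Carbonyl Carbon

A few compounds are considered here, and "the series" means these few. Any claim that something is new, unique, unknown or untested is made for them only; others in the source may bear on it.

In a functional assay on Caco-2 cells (Homo sapiens) for antiproliferative activity, read by MTT assay, with a stated time of 48 h (a higher number here means a weaker inhibitor, a lower number a stronger inhibitor), compound 1 (`C#CC(C)OC(=O)c1ccc(C(CC)(CC)c2ccc(OCCC(O)(CC)CC)c(C)c2)n1CC`) gives > 50000 nM as its reading, which is a limit and not a number. Compound 2 (`C#CCCOC(=O)c1ccc(C(CC)(CC)c2ccc(OCCC(O)(CC)CC)c(C)c2)n1CC`) gives > 50000 nM as its reading, again a limit and not a number. For the measured compounds named here, compound 3 (`CCn1c(C(=O)N(C)CC(=O)O)ccc1C(CC)(CC)c1ccc(OCCC(O)(CC)CC)c(C)c1`) gives 2740 nM as the only true number so far. The picture is framed by the limit of > 50000 nM in this assay, at which 2 of the 3 values shown sit, and compound 3 alone lies clear of it.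

Large steps appear in an at least 18-fold lower number from compound 1 to compound 3 (1.26 log units; beyond the scatter) and in an at least 18-fold lower number from compound 2 to compound 3 (1.26 log units; beyond the scatter) when (carboxymethyl)(methyl)amino replaces an oxy group on the carbonyl carbon, while a step that the two limits leave unreadable from compound 1 to compound 2 tells nothing about size.

Compound 4 (`CCC(C)C(CO)NC(=O)c1ccc(C(CC)(CC)c2ccc(OCCC(O)(CC)CC)c(C)c2)n1CC`) keeps an amino group on that carbonyl carbon, and its whole difference from compound 3 reads (1-(hydroxymethyl)-2-methylbutyl)amino in place of (carboxymethyl)(methyl)amino on a carbonyl carbon in full: (1-(hydroxymethyl)-2-methylbutyl)amino in place of (carboxymethyl)(methyl)amino. Going by the values given here, no measured step swaps one amino group for another, so the size of this change is uncertain. Compound 4 stays on the amino side of the two large steps, so it is expected to land near compound 3 at 2740 nM. Expected here is a 1.5-fold higher number from compound 3 to compound 4 (0.16 log units; within the scatter) as a slight rise in the number, not beyond the scatter. For compound 4 the estimated value is 4000 nM and 900 nM to 20000 nM is the expected range.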

Compound 4, half-maximal inhibitory concentration: > 50000 nM
Compound 4: only a limit was reported (the forecaster's own chance of this, stated with the estimate: 20%); at least 12-fold (1.09 log units) between middle value and limit.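

In this assay, putting (1-(hydroxymethyl)-2-methylbutyl)amino in place of (carboxymethyl)(methyl)amino on the carbonyl carbon gives an at least 18-fold higher number from compound 3 to compound 4 (1.26 log units; beyond the scatter), so an amino group at this place is not enough on its own to bring the reading clear of the limit, and the choice of amino group matters. Compound 4 gives > 50000 nM, which is a limit and not a number, and its steps from compound 1 and compound 2 cannot be read. Of the two amino groups shown, only (carboxymethyl)(methyl)amino comes with a true number, and compound 3 remains the only compound clear of this ceiling: the limit of > 50000 nM in this assay, at which 3 of the 4 values shown sit.

This single swap changes several features at once, so the compounds shown cannot say whether the carboxymethyl group, the methyl on the nitrogen or the branched chain accounts for the large step. A (carboxymethyl)amino group without that methyl, or a (2-hydroxyethyl)(methyl)amino group, would change fewer features at a time and help to separate these possibilities.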